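The source may report more compounds than this note shows. Statements on the series, on what has been measured and on what is new or still open speak of the compounds shown alone.

In a functional assay on SMMC-7721 cells (Homo sapiens) for antiproliferative activity, read by MTT assay, with a stated time of 72 h (on this read-out lower numbers stand for stronger inhibition and higher numbers for weaker inhibition), compound 1 `C/C(=N\NC(=O)c1cccc(S(=O)(=O)N2CCOCC2)c1)c1ccccc1O` gives 1370 nM. Compound 2 `C/C(=N\NC(=O)c1cccc(S(=O)(=O)N2CCOCC2)c1)c1cc(Br)ccc1O` differs from compound 1 in one place, (bromo in place of hydrogen on an aromatic carbon), and in this assay compound 2 gives 2410 nM; that step is a 1.8-fold higher number from compound 1 to compound 2 (0.25 log units; within the scatter). Compound 3 `O=C(N/N=C/c1cc(Br)ccc1O)c1cccc(S(=O)(=O)N2CCOCC2)c1` rests on another core, and the difference between the two cores is not broken down here; in this assay compound 3 gives 9940 nM. Compound 4 `O=C(N/N=C/c1cc(Br)cc(Br)c1O)c1cccc(S(=O)(=O)N2CCOCC2)c1` is reached from compound 3 by bromo in place of hydrogen on an aromatic carbon. Going by the values given here, this is the same kind of change as the one made from compound 1 to compound 2, though the surroundings differ: in compound 2 the bromo sits para to a hydroxy group and meta to a large group, while in compound 4 it sits ortho to a hydroxy group, meta to a bromo group and meta to a large group. Because the earlier step was a 1.8-fold higher number from compound 1 to compound 2 (0.25 log units; within the scatter), a step of similar size is expected, a 1.5-fold higher number from compound 3 to compound 4 (0.18 log units; within the scatter). Compound 4 is therefore estimated at 15000 nM, most likely between 6000 nM and 40000 nM.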

Compound 4, half-maximal inhibitory concentration: 7310 nM
Estimate against measurement, compound 4: 2.1-fold (0.31 log units) above; measured number inside the range.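

In this assay the added bromo gives a 1.4-fold lower number from compound 3 to compound 4 (0.13 log units; within the scatter) and so no real change. On these two cores, then, going from hydrogen to bromo leaves the number within the usual scatter, but two small steps in different surroundings cannot show that this holds on any other core in the series. Within that limit the change carries over between the two cores, with no measurable difference between them: the same change on two cores in this assay, a 1.8-fold higher number (0.25 log units; within the scatter) from compound 1 to compound 2 and a 1.4-fold lower number (0.13 log units; within the scatter) from compound 3 to compound 4, 2.4-fold (0.38 log units) apart, within the scatter of two such steps.

The compounds shown leave open whether another group at the same place, such as an amine, a carboxylic acid or a longer chain, would move the number beyond the scatter.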